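This account rests on a few compounds, and the source may have more. Where it says the series, first, only, none or still open, it means among the compounds named here.

In a functional assay on MDA-MB-231 cells (Homo sapiens) for cytotoxicity, read by MTT assay, with a stated time of 48 h (on this read-out lower numbers stand for stronger inhibition and higher numbers for weaker inhibition), compound 1 (`COc1cc(/C=C/c2ccc(OCCCCC(=O)NO)cc2)cc(OC)c1`) gives 4210 nM, compound 2 (`COc1cc(/C=C/c2ccc(OCCCCCC(=O)NO)cc2)cc(OC)c1`) gives 3560 nM and compound 3 (`COc1cc(/C=C/c2ccc(OCc3ccccc3C(=O)NO)cc2)cc(OC)c1`) gives 7180 nM. Compound 3 therefore stands level with the other two, since no gap among the three goes beyond the scatter.

Compound 4 (`COc1cc(/C=C/c2ccc(OCc3cccc(C(=O)NO)c3)cc2)cc(OC)c1`) has the same atoms, joined differently: 3-(hydroxycarbamoyl)phenyl in place of 2-(hydroxycarbamoyl)phenyl on a saturated chain carbon bound to an oxygen on an aromatic ring. Going by the values given here, no measured step covers this exact exchange on a saturated chain carbon bound to an oxygen on an aromatic ring. The closest evidence comes from replacing the saturated chains with 2-(hydroxycarbamoyl)phenyl, which gave a 1.7-fold higher number from compound 1 to compound 3 (0.23 log units; within the scatter) and a 2.0-fold higher number from compound 2 to compound 3 (0.30 log units; within the scatter). Extending the chain gave a 1.2-fold lower number from compound 1 to compound 2 (0.07 log units; within the scatter). All three steps lie within the scatter, so no step beyond the scatter is expected in this assay, and no direction is firmly indicated.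

The estimated step is a 1.4-fold lower number from compound 3 to compound 4 (0.16 log units; within the scatter), which is expected to stay within the scatter. For compound 4 the expected value is 5000 nM, with an estimated range from 2200 nM to 11000 nM.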

Compound 4, half-maximal inhibitory concentration: 9220 nM
Beside the measured number, compound 4's estimate is 1.8-fold (0.27 log units) below it; measured number inside the range.
By their numbers in this assay, from the lowest: compounds 2, 1, 3 and 4 (each within the scatter of the next, the first and the last beyond it).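

In this assay the two ring isomers stay level, since 3-(hydroxycarbamoyl)phenyl in place of 2-(hydroxycarbamoyl)phenyl gives a 1.3-fold higher number from compound 3 to compound 4 (0.11 log units; within the scatter) and so shows no clear effect of this change on its own. Going by these compounds alone, a ring-bearing linker now separates from the saturated chains for the first time, though only modestly: 3-(hydroxycarbamoyl)phenyl in place of 4-(hydroxycarbamoyl)butyl gives a 2.6-fold higher number from compound 2 to compound 4 (0.41 log units; beyond the scatter) and in place of 3-(hydroxycarbamoyl)propyl gives a 2.2-fold higher number from compound 1 to compound 4 (0.34 log units; beyond the scatter) while compound 3 had stayed within the scatter of both chains. Nothing at hand explains these differences.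

The compounds shown leave open how 4-(hydroxycarbamoyl)phenyl would compare at this place, and whether a chain longer than 4-(hydroxycarbamoyl)butyl would differ from the two chains shown. They also leave open what a carboxylic acid in place of the hydroxycarbamoyl group would give.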